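Swapping the prenyl ether for a propargyl ether: cytotoxicity

The source may report more compounds than this note shows. Statements on the series, on what has been measured and on what is new or still open speak of the compounds shown alone.

The measured compounds:
Compound 1, `CC(C)=CCOc1ccc(C(=O)/C=C/c2cccnc2)c(O)c1`: 100000 nM
Compound 2, `COc1cc(OCC=C(C)C)ccc1C(=O)/C=C/c1ccncc1`: 16000 nM
Compound 3, `C#CCOc1ccc(C(=O)/C=C/c2cccnc2)c(O)c1`: 25000 nM

These three chalcone-type compounds were tested in an ADME assay on THP-1 cells (Homo sapiens) for cytotoxicity, read by resazurin assay, with a stated time of 72 h; a higher number here means that more compound is tolerated, a lower number that less compound is tolerated. Compound 1 sits at the high end of the three numbers, and from compound 1 to compound 3 a 4.0-fold lower number from compound 1 to compound 3 (0.60 log units; beyond the scatter): the change is ethynyl in place of 2-methylprop-1-en-1-yl on a saturated chain carbon bound to an oxygen on an aromatic ring. Compound 2 has the lowest of the three numbers, though it is within the scatter of compound 3. How the core of compound 2 differs from the core of compound 1 is not broken down here.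

Compound 4, `C#CCOc1ccc(C(=O)/C=C/c2ccncc2)c(OC)c1`, has not yet been measured in this assay. It relates to compound 2 as compound 3 relates to compound 1: ethynyl in place of 2-methylprop-1-en-1-yl on a saturated chain carbon bound to an oxygen on an aromatic ring. Because the earlier step gave a 4.0-fold lower number from compound 1 to compound 3 (0.60 log units; beyond the scatter), a step of similar size, a 3.2-fold lower number from compound 2 to compound 4 (0.51 log units; beyond the scatter), is expected on the core of compound 2, with some allowance for the core being different. The expected value for compound 4 in this assay is therefore 5000 nM, with a likely range from 2000 nM to 16000 nM.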

Compound 4, half-maximal cytotoxic concentration: 16000 nM
Estimate against measurement, compound 4: 3.2-fold (0.51 log units) below, and the stated range covers the measured number.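

On the core of compound 2, the same ether swap, 3-methylbut-2-en-1-yl to propargyl, gives no change at the digits printed from compound 2 to compound 4 (within the scatter) in this assay. The change therefore does not carry over from one core to the other at a fixed size, and the gap between the two steps is larger than repeat measurements would explain: the same change on two cores in this assay, a 4.0-fold lower number (0.60 log units; beyond the scatter) from compound 1 to compound 3 and no change at the digits printed (within the scatter) from compound 2 to compound 4, 4.0-fold (0.60 log units) apart, beyond the scatter of two such steps. This shows that the effect of the swap on tolerated concentration depends on the core it is made on, but two pairs of compounds cannot show why, nor predict the size of the step on a further core.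

The compounds shown leave open which feature of the two cores accounts for the gap, as no compound separates one feature from another. Also open, on these data alone, is how other groups on the same ether oxygen, such as a longer chain or a chain ending in an amine, would behave on either core.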